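Swapping tert-butyl for (trifluoromethyl)sulfanyl on a urea

A few compounds are considered here, and "the series" means these few. Any claim that something is new, unique, unknown or untested is made for them only; others in the source may bear on it.

Measured compounds:
compound 1 `Cc1cc(NC(=O)Nc2ccc(C(C)(C)C)cc2)c2ccccc2n1`, > 25000 nM
compound 2 `Cc1cc(NC(=O)Nc2ccc(Cl)c(Cl)c2)c2ccccc2n1`, 10000 nM
compound 3 `COc1ccc(NC(=O)Nc2cc(C)nc3ccccc23)cc1F`, > 25000 nM

Of the compounds shown here, three sharing the same core have been tested in an ADME assay on Raji cells (Homo sapiens) for cytotoxicity, with a stated time of 72 h; on this read-out higher numbers stand for an effect only at larger amounts of compound and lower numbers for an effect already at smaller amounts. For compound 1 the result is only a limit of the assay, > 25000 nM. For compound 3 the result is likewise a limit, > 25000 nM. For the measured compounds named here, compound 2 is the one compound of the three with a number, giving 10000 nM in this assay. Compound 1 therefore sits at the edge of what this assay can report, and the same holds for compound 3; the value for compound 2 lies at the weak end of the measured scale.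

The step to be followed goes from compound 1 to compound 4 `Cc1cc(NC(=O)Nc2ccc(SC(F)(F)F)cc2)c2ccccc2n1`: (trifluoromethyl)sulfanyl in place of tert-butyl on an aromatic carbon. No comparable single change has been measured among the three compounds shown, so the size of the step cannot be read from data. Given that compound 1 stands at the limit of > 25000 nM in this assay, at which 2 of the 3 values shown sit, the expectation is for a step from compound 1 to compound 4 of an at least 1.1-fold lower number from compound 1 to compound 4 (0.05 log units; that floor lies within the scatter), that is, no shift beyond the scatter. Compound 4 is expected to give about 22000 nM in this assay, within a range from 7000 nM to 60000 nM.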

Compound 4, half-maximal effective concentration: 10000 nM
For compound 4 the middle estimate is 2.2-fold (0.34 log units) above the measured one; the range from low to high includes it.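

In this assay compound 1 gives only a limit, > 25000 nM. Compound 4 gives an actual number, 10000 nM, and the change of tert-butyl to (trifluoromethyl)sulfanyl on this aromatic carbon amounts to an at least 2.5-fold lower number from compound 1 to compound 4 (0.39 log units; beyond the scatter), so a single swap of group at this place is enough to bring the cytotoxic effect into the range the assay can report. This is the only single change that can be read among the compounds shown, and its figure is a minimum rather than a true size, because one end of the comparison is a limit: the limit of > 25000 nM in this assay, at which 2 of the 4 values shown sit.

One pair of compounds cannot tell which feature of the entering group goes with the step, since the two groups differ in several ways at once and nothing shown separates them. Going by these compounds, it also remains open how the number would respond at this same place to an amine, a carboxylic acid or a longer carbon chain, and so whether the step from tert-butyl reflects a trend or holds for this one group alone.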